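This account rests on a few compounds, and the source may have more. Where it says the series, first, only, none or still open, it means among the compounds named here.

Measured so far in a toxicity assay on THP-1 cells (Homo sapiens) for inhibition; a lower number here means that less compound is tolerated, a higher number that more compound is tolerated:
- Compound 1 `COc1ccccc1-c1cnc(NC(=O)c2ccc(F)cc2)n1C` — > 100000 nM, a limit of the assay.
- Compound 2 `Cn1c(-c2cccc(Br)c2)cnc1NC(=O)c1ccc(F)cc1` — > 50000 nM, a limit of the assay.
- Compound 3 `COc1ccc(-c2cnc(NC(=O)c3ccc(F)cc3)n2C)cc1` — >= 50000 nM, a limit of the assay.

Compound 3 stands only on a limit, and the two further values shown are limits as well (the limit of > 100000 nM in this assay, at which 1 of the 3 values shown sits; (the limit of > 50000 nM in this assay, at which 1 of the 3 values shown sits); (the limit of >= 50000 nM in this assay, at which 1 of the 3 values shown sits)). The three measured steps, a step that the two limits leave unreadable from compound 1 to compound 2, a step that the two limits leave unreadable from compound 1 to compound 3 and a step that the two limits leave unreadable from compound 2 to compound 3, all exchange the aryl on the aromatic carbon and none has a readable size.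

Compound 4 `COc1ccc(-c2cnc(NC(=O)c3ccccc3O)n2C)cc1` is not yet measured. It differs from compound 3 by 2-hydroxyphenyl in place of 4-fluorophenyl on a carbonyl carbon. Going by the values given here, no measured step touches the carbonyl side of the shared core; the only guidance is that every measured compound sits at a limit in this assay. The expected step is therefore a step that the limit leaves unreadable from compound 3 to compound 4, with no reading in either direction beyond the scatter. Compound 4 is estimated at 80000 nM, within a range from 25000 nM to 250000 nM, and most probably reported again only as a limit.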

Compound 4, half-maximal cytotoxic concentration: > 100000 nM
Compound 4: a limit, no number (the forecaster's own chance of this, stated with the estimate: 70%); middle value at least 1.2-fold (0.09 log units) from the limit.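

In this assay compound 4 gives > 100000 nM, a limit of the assay. Going by these compounds alone, compound 3 also stands on a limit, so no step from compound 3 to compound 4 can be read. The compounds shown leave open whether 2-hydroxyphenyl in place of 4-fluorophenyl on a carbonyl carbon changes tolerance at all.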